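Methylating the Ring Nitrogen of Compound 2

This account rests on a few compounds, and the source may have more. Where it says the series, first, only, none or still open, it means among the compounds named here.

Compound 1 `O=C(Nc1ccc(Oc2ccnc3[nH]ccc23)cc1)c1cc2cccnc2n(-c2ccc(Br)cc2)c1=O` and compound 2 `O=C(Nc1ccc(Oc2ccnc3[nH]ccc23)c(F)c1)c1cc2cccnc2n(-c2ccc(Br)cc2)c1=O` share one core and differ only at one aromatic carbon. In a functional assay on HT-29 cells (Homo sapiens) for antiproliferative activity, read by MTT assay, with a stated time of 72 h (a lower number here means a stronger inhibitor, a higher number a weaker inhibitor), compound 1 gives 270 nM, while compound 2 gives 120 nM. This is the step of a 2.3-fold lower number from compound 1 to compound 2 (0.35 log units; beyond the scatter). Compound 2 therefore stands with the lowest of the two numbers, and compound 1 is its nearest neighbour at a higher number.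

Compound 3 `Cn1ccc2c(Oc3ccc(NC(=O)c4cc5cccnc5n(-c5ccc(Br)cc5)c4=O)cc3F)ccnc21` differs from compound 2 by methyl in place of hydrogen on an aromatic nitrogen. Going by the values given here, the single measured step concerns fluoro replacing hydrogen on an aromatic carbon in another part of the molecule, so no measured step bears on a methyl placed on a ring nitrogen, and the data give no direction. The expected change from compound 2 to compound 3 in this assay is a modest weakening, a 2.9-fold higher number from compound 2 to compound 3 (0.46 log units; beyond the scatter), held with a wide range. Compound 3 is estimated at 350 nM, expected between 80 nM and 2500 nM.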

Compound 3, half-maximal inhibitory concentration: 330 nM
Beside the measured number, compound 3's estimate is 1.1-fold (0.03 log units) above it; measured number inside the range.
By their numbers in this assay, from the lowest: compound 2; then compounds 1 and 3 (each within the scatter of the next).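

In this assay, putting methyl in place of hydrogen on the aromatic nitrogen of the five-membered ring gives a 2.8-fold higher number from compound 2 to compound 3 (0.44 log units; beyond the scatter) and so undoes the gain seen with fluoro, showing that the number responds to a change at this nitrogen as well as at the aromatic carbon. The step is modest, and with a methyl on that nitrogen compound 3 still gives 330 nM, so the hydrogen there is not essential for activity in these cells. Nothing available here accounts for the rise in the number.

From the compounds shown here alone, whether a longer chain such as ethyl, or a chain ending in an amine or a carboxylic acid, would move the number further on this nitrogen stays open. So does the size of the methyl step on the core of compound 1, which carries hydrogen in place of fluoro.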